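The compounds below may be only part of what the source reports. "The series", "measured", "known", "first", "only" and "open" are said of these compounds alone.

Compound 1 `COc1ccc(C(OCc2ccccc2)c2cccc3ccccc23)c(OC)c1OC` carries a benzyloxy group on the carbon that joins its two aromatic parts. In a functional assay on MCF7 cells (Homo sapiens) for inhibition, read by sulforhodamine B assay, with a stated time of 48 h (on this read-out lower numbers stand for stronger inhibition and higher numbers for weaker inhibition), compound 1 gives 14100 nM. Its closest neighbour among the numbers shown is compound 2 `C=C(c1ccc(OC)c(OC)c1OC)c1cccc2ccccc12`, which in this assay gives 11700 nM; the two values sit together, with a gap that lies within the usual scatter of repeated measurements, so neither can be called the stronger of the pair. Compound 3 `COc1ccc(/C(=C/c2ccc(C)cc2)c2cccc3ccccc23)c(OC)c1OC` is reported in this assay only as a limit of the assay, > 20000 nM, and not as a number; that is the limit of > 20000 nM in this assay, at which 1 of the 3 values shown sits.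

Compound 4 `COc1ccc(C(OCc2ccc(C)cc2)c2cccc3ccccc23)c(OC)c1OC` has not yet been measured. It differs from compound 1 in one place: methyl in place of hydrogen on an aromatic carbon. Within the data shown here, no measured pair among compounds 1, 2 and 3 shows exactly this change, so there is no measured step to lean on, and the two numbers that exist lie close to each other. The expectation is therefore a step of no more than the scatter, in either direction, from compound 1 to compound 4, written as a 1.1-fold higher number from compound 1 to compound 4 (0.03 log units; within the scatter). On that basis compound 4 is estimated in this assay at 15000 nM, with a likely range from 6000 nM to 40000 nM.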

Compound 4, half-maximal inhibitory concentration: 10700 nM
The estimate for compound 4 lay 1.4-fold (0.15 log units) above the measured number; the measured number falls inside the stated range.
By their numbers in this assay, from the lowest: compounds 4, 2 and 1 (each within the scatter of the next). At a limit, above all of these: compound 3.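

In this assay, among these compounds, the change from benzyloxy to (4-methylbenzyl)oxy gives a 1.3-fold lower number from compound 1 to compound 4 (0.12 log units; within the scatter), the first step in this set that can be read at a single place. The methyl group, set para to a large group on the aromatic ring, therefore leaves the number where it was as far as repeated measurements of this kind can tell, so this position accepts this one small addition with no change that can be distinguished from the scatter. Compound 3 remains a limit of the assay and not a number: the limit of > 20000 nM in this assay, at which 1 of the 4 values shown sits.

A single methyl cannot show whether this position responds to substitution at all, and a chlorine, a methoxy group, an amine or a carboxylic acid in the same place might or might not move the number beyond the scatter. The compounds shown also leave open whether a longer chain in place of the benzyl group's single carbon link would matter, and they give no way to explain why the core of compound 1 sits at this level of inhibition.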